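The compounds below may be only part of what the source reports. "The series", "measured", "known", "first", "only" and "open" are said of these compounds alone.

Values in an ADME assay on HUVEC cells (Homo sapiens) for inhibition, read by MTT assay, with a stated time of 48 h; on this read-out lower numbers stand for stronger inhibition and higher numbers for weaker inhibition:
- Compound 1 `Fc1ccc(/C=N/Nc2nc(-c3ccc(F)c(F)c3)cs2)cc1F`: 59700 nM
- Compound 2 `Fc1ccc(/C=N/Nc2nc(-c3cccc(Br)c3)cs2)cc1F`: > 100000 nM (a limit of the assay, not a number)

Compound 2 has no exact position in this assay. Its > 100000 nM is only a limit. the limit of > 100000 nM in this assay, at which 1 of the 2 values shown sits.

Compound 3 `Fc1ccc(/C=N/Nc2nc(-c3ccccc3)cs2)cc1F` follows from compound 2 with hydrogen in place of bromo on an aromatic carbon, meta to a large group: hydrogen in place of bromo on an aromatic carbon.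

Among the measured compounds shown here, one measured step bears on this, and only loosely, as it changes the same aryl group in a different way: an at least 1.6-fold higher number from compound 1 to compound 2 (0.22 log units; that floor lies within the scatter). For the measured compounds named here, it gives a floor, not a size, and no measured step shows the removal of bromo alone. Compound 3 is therefore expected to stay in the weak range, with compound 1 at 59700 nM as the nearest numerical anchor. The expected step is modest, towards lower numbers if any can be read at all: an at least 1.4-fold lower number from compound 2 to compound 3 (0.15 log units; that floor lies within the scatter). Compound 3 is estimated at 70000 nM, with an expected range from 25000 nM to 180000 nM.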

Compound 3, half-maximal inhibitory concentration: > 100000 nM
Compound 3 was reported as a limit; the forecaster's own chance of this, stated with the estimate: 35%; at least 1.4-fold (0.15 log units) between middle value and limit.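

Removing bromo from this aryl group brings no measurable value into reach in this assay: compound 3 gives > 100000 nM, a limit of the assay and not a number. The size of the change from 3-bromophenyl to phenyl cannot be read, and compound 2 and compound 3 rest on the same ceiling: the limit of > 100000 nM in this assay, at which 2 of the 3 values shown sit. Phenyl in place of 3,4-difluorophenyl gives an at least 1.6-fold higher number from compound 1 to compound 3 (0.22 log units; that floor lies within the scatter), the same floor as seen with 3-bromophenyl, so among these three only the 3,4-difluorophenyl compound carries an exact number.

Open, going by these compounds, is whether an amine or a carboxylic acid on this aryl group would move the number clearly away from that of compound 1 at 59700 nM. Also open, on these data alone, is how far compound 2 and compound 3 lie past their limits, and so whether bromo matters at all here.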